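The compounds below may be only part of what the source reports. "The series", "measured", "known", "first", "only" and "open" are said of these compounds alone.

Compounds measured in a functional assay on the whole organism (strain Sprague-Dawley CD) for inhibition, with Rattus norvegicus as the target, read by paw edema, at a dose of 30 mg/kg by the intraperitoneal route; a lower number here means a weaker effect, a higher number a stronger effect of the compound at the dose given:

compound 1 `CCOC(=O)C(=O)Nc1cccccc1=O` gives 84%
compound 2 `CCOC(=O)C(=O)Nc1ccc(O)c(=O)cc1` gives 10%
compound 3 `CCOC(=O)C(=O)Nc1ccccc(Br)c1=O` gives 52%

Compound 1 stands highest of the three numbers in this assay. Its nearest neighbour is compound 3, reached by the step of a number 32 percentage points lower from compound 1 to compound 3 (beyond the scatter), which is bromo in place of hydrogen on an aromatic carbon of the shared core. Within the data shown here, compound 2, with a hydroxy group and a different substitution pattern, lies furthest away; its value is far lower than that of compound 1, and no single step connects the two.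

Compound 4 `CCOC(=O)C(=O)Nc1ccccc(OC)c1=O` differs from compound 1 in one place: methoxy in place of hydrogen on an aromatic carbon. Among the measured compounds shown here, the only measured step that bears on this is the one from compound 1 to compound 3, where a bromo entered at the same kind of site and gave a large drop. A methoxy entering there has not been tried, so the direction of the bromo step is the guide, with the size left open. The expectation is therefore a drop beyond the scatter in this assay, of the order of a number 29 percentage points lower from compound 1 to compound 4 (beyond the scatter). For compound 4 the estimate is 55%, within a range of 25% to 80%.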

Compound 4, a percentage reported as inhibition, in the whole organism at one dose (the size of the read-out at that dose, not a potency): 52%
Compound 4: middle estimate off by 3 percentage points, on the high side; low and high end bracket the measured number.
By their numbers in this assay, from the lowest: compound 2; then compounds 3 and 4 (each within the scatter of the next); then compound 1.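

In this assay, a second group now stands on the aromatic carbon two ring bonds from the ring atom that bears the group of 8 heavy atoms: methoxy in place of hydrogen gives a number 32 percentage points lower from compound 1 to compound 4 (beyond the scatter), so the loss at this position is not peculiar to bromo. Methoxy in place of bromo gives no change at the digits printed from compound 3 to compound 4 (within the scatter), and this read-out at this dose does not separate the two groups. No measurement here accounts for the drop at this position.

On these data alone, it remains open whether an amine, a carboxylic acid or a longer alkoxy chain at the same carbon would match compound 3 and compound 4 or stay near compound 1 at 84% in this assay. As far as these compounds go, whether the same picture holds at other doses also remains open.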